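Aryl-substituted pyrazoline series: fluoro to methoxy step

The source may hold more compounds than are shown below. What is called first, only, known or untested is meant among the compounds shown, and "the series" means these compounds.

Measured so far in a functional assay on BGC-823 cells (Homo sapiens) for inhibition, read by CCK-8 assay, with a stated time of 48 h; a higher number here means a weaker inhibitor, a lower number a stronger inhibitor:
- compound 1, `Fc1ccc(C2=NN(C3=NC(c4ccccc4)CS3)C(c3cccc4ccccc34)C2)cc1`, gives 22700 nM
- compound 2, `Cc1ccc(C2=NN(C3=NC(c4ccccc4)CS3)C(c3ccc4ccccc4c3)C2)cc1C`, gives 6570 nM
- compound 3, `O=C1CSC(N2N=C(c3ccc(F)cc3)CC2c2cccc3ccccc23)=N1`, gives 19300 nM

Compound 3 stands second highest of the three numbers in this assay. Its nearest neighbour is compound 1: the step of a 1.2-fold lower number from compound 1 to compound 3 (0.07 log units; within the scatter) lies within the scatter, so the two values cannot be ordered. Among the compounds with values here, compound 2 gives the lowest number of the three, beyond the scatter from compound 3, but compound 2 differs from compound 3 in more than one place and no single step is drawn between them.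

Compound 4, `COc1ccc(C2=NN(C3=NC(=O)CS3)C(c3cccc4ccccc34)C2)cc1`, differs from compound 3 by methoxy in place of fluoro on an aromatic carbon. Within the data shown here, no measured pair isolates this change. Among the measured compounds shown here, the only step available, from compound 1 to compound 3, concerns the ring on the amine nitrogen and not the substituent on the six-membered aromatic ring of carbon only, so it does not bear on the present change. For the measured compounds named here, with no relevant step, the expectation is for no change beyond the scatter in this assay, a step of a 1.3-fold lower number from compound 3 to compound 4 (0.11 log units; within the scatter).

Compound 4 is therefore expected to give about 15000 nM, within a range of 6000 nM to 40000 nM, in this assay.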

Compound 4, half-maximal inhibitory concentration: 8210 nM
The estimate for compound 4 lay 1.8-fold (0.26 log units) above the measured number, and the stated range covers the measured number.
By their numbers in this assay, from the lowest: compounds 2 and 4 (each within the scatter of the next); then compounds 3 and 1 (each within the scatter of the next).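

In this assay, the aromatic carbon para to a large group responds to its substituent: 4-fluorophenyl to 4-methoxyphenyl gives a 2.4-fold lower number from compound 3 to compound 4 (0.37 log units; beyond the scatter) on the shared core, a modest change but beyond the scatter. The only earlier single-place step, a 1.2-fold lower number from compound 1 to compound 3 (0.07 log units; within the scatter) when the group on the amine nitrogen in a ring is exchanged, stays within the scatter, so this is the first change in the series shown to move the number measurably, and the value of compound 4 now sits within the scatter of the lowest value in the set. No measurement at hand bears on what lies behind this step.

From the compounds shown here alone, whether the same exchange gives a step of similar size on the core of compound 1, with its larger group on the amine nitrogen, remains open, as a single pair cannot show how far the effect carries to other members. Also open, going by these compounds, is how the position reads with other groups, such as a hydroxyl, an ethoxy, a chloro or an amine, and whether methoxy placed elsewhere on the same ring gives a comparable number.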